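From 3-fluorophenyl to 2-hydroxyphenyl on a shared core

This account rests on a few compounds, and the source may have more. Where it says the series, first, only, none or still open, it means among the compounds named here.

In a functional assay (Homo sapiens) for inhibition (on this read-out lower numbers stand for stronger inhibition and higher numbers for weaker inhibition), compound 1 (`COc1ccc(C(=O)/C=C/c2ccccc2F)c(OC)c1OC`) gives 11000 nM and compound 2 (`COc1ccc(C(=O)/C=C/c2cccc(F)c2)c(OC)c1OC`) gives 6400 nM, so the two stand within the scatter of each other. Compound 3 (`COc1ccc(C(=O)/C=C/c2ccccc2O)c(OC)c1OC`) has 2-hydroxyphenyl in place of the 3-fluorophenyl of compound 2: 2-hydroxyphenyl in place of 3-fluorophenyl on a double-bonded chain carbon bound to a double-bonded chain carbon. Within the data shown here, the only measured step, a 1.7-fold lower number from compound 1 to compound 2 (0.24 log units; within the scatter), exchanges 2-fluorophenyl for 3-fluorophenyl and stays within the scatter, and no measured compound carries 2-hydroxyphenyl. The expected change is therefore none beyond the scatter in this assay, an estimated 1.1-fold higher number from compound 2 to compound 3 (0.04 log units; within the scatter). Compound 3 is expected at 7000 nM, with an estimated range of 2000 nM to 25000 nM.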

Compound 3, half-maximal inhibitory concentration: 9000 nM
Compound 3: middle estimate off by 1.3-fold (0.11 log units), on the low side; low and high end bracket the measured number.
By their numbers in this assay, from the lowest: compounds 2, 3 and 1 (each within the scatter of the next).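

In this assay the change from a fluoro group to a hydroxy group, which adds a hydrogen-bond donor and acceptor, gives a 1.4-fold higher number from compound 2 to compound 3 (0.15 log units; within the scatter) when 2-hydroxyphenyl replaces 3-fluorophenyl. The closer comparison, hydroxy in place of fluoro on an aromatic carbon, gives a 1.2-fold lower number from compound 1 to compound 3 (0.09 log units; within the scatter) and so also stays within the scatter, showing that this position can carry more than a moved fluoro group without a clear shift in the number. No supporting data explain this result. Going by these compounds, whether an amine or a carboxylic acid on this ring would shift the number beyond the scatter remains open.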